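Aromatic group in place of saturated group at the ring nitrogen

The source may report more compounds than this note shows. Statements on the series, on what has been measured and on what is new or still open speak of the compounds shown alone.

For the measured compounds named here, compound 2 `Cc1cccc2sc(NC(=O)CCN3CCN(CC4CCCCC4)CC3)nc12` gives 519 nM in an assay on membranes from liver for displacement of a labelled ligand from Sigma intracellular receptor 2 (Rattus norvegicus), read by scintillation counting, with a stated time of 120 min (on this read-out higher numbers stand for weaker inhibition and lower numbers for stronger inhibition), and is the only member with a full number. Compound 1 `Cc1cccc2sc(NC(=O)CCN3CCN(CCN(C)C)CC3)nc12` returns only the assay limit > 1000 nM in this assay. The step of an at least 1.9-fold lower number from compound 1 to compound 2 (0.28 log units; that floor lies within the scatter) therefore rests on one side on the limit of > 1000 nM in this assay, at which 1 of the 2 values shown sits, and its true size is not fixed. Compound 3 `Cc1cccc2sc(NC(=O)CCN3CCN(c4ccncc4)CC3)nc12` is the unmeasured member; it differs from compound 2 by pyridin-4-yl in place of cyclohexylmethyl on an amine nitrogen in a ring. Going by the values given here, the single measured step concerns the same ring nitrogen but exchanges one saturated group for another, so it gives little guidance on the present change, in which an aromatic group enters. No measured comparison in this set reports an aromatic group at this position, and the direction must be taken as open. For compound 3 a moderate rise in the number is expected, a 2.3-fold higher number from compound 2 to compound 3 (0.36 log units; beyond the scatter), with broad uncertainty on both sides. The estimate for compound 3 in this assay is 1200 nM, within 350 nM to 4500 nM, and a fair chance remains that only the limit is returned.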

Compound 3, inhibition constant: 1700 nM
Compound 3: middle estimate off by 1.4-fold (0.15 log units), on the low side; low and high end bracket the measured number.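

In this assay, for the compounds shown here, pyridin-4-yl in place of cyclohexylmethyl gives a 3.3-fold higher number from compound 2 to compound 3 (0.52 log units; beyond the scatter) as the first comparison at this ring nitrogen with full numbers at both ends, and the first with an aromatic group entering. Compound 3 gives 1700 nM as a full number, so a directly attached pyridin-4-yl still returns a reading in this series, though the change also removes the carbon link that cyclohexylmethyl carries and brings a ring nitrogen into the group. Compound 1 gives > 1000 nM as a limit of the assay, so its step to compound 3 cannot be read: the limit of > 1000 nM in this assay, at which 1 of the 3 values shown sits.

Going by these compounds alone, the single step does not separate the effect of the aromatic ring from that of the lost carbon link or the pyridine nitrogen; phenyl, benzyl and pyridin-4-ylmethyl at the same ring nitrogen would pull these three apart. On these data alone, it also remains open whether pyridin-2-yl or pyridin-3-yl would read like pyridin-4-yl, and whether any group at this position gives a lower number than cyclohexylmethyl in compound 2.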